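The source may report more compounds than this note shows. Statements on the series, on what has been measured and on what is new or still open speak of the compounds shown alone.

Of the compounds shown here, three of a shared core have already been measured in a physicochemical assay for solubility, read by HPLC, at pH 6.8; a lower number here means a less soluble compound, a higher number a more soluble compound. Compound 1, `CC(C)(C)c1cc(NC(=O)[C@@H]2CCCCN2C2CC2)no1`, gives 38 ug/mL. Compound 2, `CC(C)(C)c1cc(NC(=O)[C@@H]2CCCCN2C(=O)c2ccc(Cl)cc2)no1`, reaches only the limit of this assay, < 0.1 ug/mL, which is a limit and not a number. Compound 3, `CC(C)(C)c1cc(NC(=O)[C@@H]2CCCCN2C(=O)C2CCOCC2)no1`, gives 48 ug/mL, the highest of the two numbers shown, with compound 1 nearest at a difference that lies within the scatter (a 1.3-fold higher number from compound 1 to compound 3 (0.10 log units; within the scatter)). Compound 4, `CC(C)(C)c1cc(NC(=O)[C@@H]2CCCCN2C(=O)N2CCCCC2)no1`, differs from compound 3 by piperidin-1-yl in place of oxan-4-yl on a carbonyl carbon. Among the measured compounds shown here, two measured steps bear on this position: a 1.3-fold higher number from compound 1 to compound 3 (0.10 log units; within the scatter), which was small, and an at least 480-fold higher number from compound 2 to compound 3 (2.68 log units; beyond the scatter), which was large; in the latter a six-membered saturated ring replaced a chlorinated aromatic one, whereas here one six-membered saturated ring replaces another, and the limit of < 0.1 ug/mL in this assay, at which 1 of the 3 values shown sits, marks only where compound 2 sits. A step within the scatter is therefore expected, a 1.6-fold lower number from compound 3 to compound 4 (0.20 log units; within the scatter), with no clear direction. Compound 4 is estimated at 30 ug/mL, between 8 ug/mL and 100 ug/mL.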

Compound 4, solubility: 49 ug/mL
The estimate for compound 4 lay 1.6-fold (0.21 log units) below the measured number; low and high end bracket the measured number.
By their numbers in this assay, from the lowest: compounds 1, 3 and 4 (each within the scatter of the next). At a limit, below all of these: compound 2.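

The oxygen of oxan-4-yl and the nitrogen of piperidin-1-yl can be exchanged on this carbonyl carbon with no reading beyond the scatter, even though the hydrogen-bond acceptor counted on oxan-4-yl is absent from piperidin-1-yl: a 1.0-fold higher number from compound 3 to compound 4 (0.01 log units; within the scatter), and against the cyclopropyl group the result is much the same, a 1.3-fold higher number from compound 1 to compound 4 (0.11 log units; within the scatter). A second saturated six-membered ring now stands apart from 4-chlorophenyl by a large step, an at least 490-fold higher number from compound 2 to compound 4 (2.69 log units; beyond the scatter), so this contrast no longer rests on compound 3 alone. The size of that step is only a bound, as compound 2 sits at a limit and not a number: the limit of < 0.1 ug/mL in this assay, at which 1 of the 4 values shown sits.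

A plain phenyl without chlorine would show whether the large step follows the aromatic ring or the chlorine. On these data alone, whether an amine or a carboxylic acid on the outer ring would move the number also stays open.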